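The source may report more compounds than this note shows. Statements on the series, on what has been measured and on what is new or still open speak of the compounds shown alone.

Working notes on the series. In a functional assay on M14 cells (Homo sapiens) for inhibition, read by sulforhodamine B assay, with a stated time of 48 h (on this read-out higher numbers stand for weaker inhibition of growth and lower numbers for stronger inhibition of growth), compound 1 `O=C(Nc1cccc(-n2cc(-c3ccncc3)c(-c3ccc(Cl)c(O)c3)n2)c1)Nc1ccc(Cl)c(Cl)c1` gives 6970 nM. Compound 2 `COc1cc(-c2nn(-c3cccc(NC(=O)c4cccc(C(F)(F)F)c4)c3)cc2-c2ccncc2)ccc1Cl` reaches only a limit of this assay and reports > 50000 nM; this is the limit of > 50000 nM in this assay, at which 1 of the 2 values shown sits, not a number, so compound 2 stands at the weak end of what is shown. Compound 3 `COc1cc(-c2nn(-c3cccc(NC(=O)c4ccccc4)c3)cc2-c2ccncc2)ccc1Cl` differs from compound 2 by hydrogen in place of trifluoromethyl on an aromatic carbon, benzoyl replacing (3-(trifluoromethyl)phenyl)carbonyl. Among the measured compounds shown here, no measured step speaks to this change, so the step from compound 2 to compound 3 is expected to be small, within the scatter of this assay, with a number no higher from compound 2 to compound 3 (the limit leaves the size open). For compound 3 the expected value is 50000 nM, in the range 15000 nM to 150000 nM, most likely again a limit.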

Compound 3, concentration for total growth inhibition: 12900 nM
Estimate against measurement, compound 3: 3.9-fold (0.59 log units) above; the whole stated range lies above it.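

In this assay, hydrogen in place of trifluoromethyl on this aromatic carbon gives an at least 3.8-fold lower number from compound 2 to compound 3 (0.58 log units; beyond the scatter). Among the compounds shown here, this is the first measured change at this position, and it shows that the phenyl compound, unlike the 3-(trifluoromethyl)phenyl compound, gives a number rather than a limit. The true size of the step stays unknown, as one end of it is not a number: the limit of > 50000 nM in this assay, at which 1 of the 3 values shown sits.

Going by these compounds, what a single fluorine, a methyl or an amine would give on this carbon stays open. So does whether the step would hold with other groups elsewhere on the shared core.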